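From benzoxazole to benzothiophene on a shared core

The source may report more compounds than this note shows. Statements on the series, on what has been measured and on what is new or still open speak of the compounds shown alone.

Compound 1 `Nc1ccc(S(=O)(=O)N2CCN(c3ncc(C(O)(C(F)(F)F)C(F)(F)F)cc3C3CC3)CC2)cn1`: 27 mL.min-1.g-1
Compound 2 `Cc1nc2cc(-c3cc(C(O)(C(F)(F)F)C(F)(F)F)cnc3N3CCN(S(=O)(=O)c4ccc(N)nc4)CC3)ccc2o1`: 99 mL.min-1.g-1

In an ADME assay (liver) for metabolic stability, with Liver microsome (Rattus norvegicus) as the target, using microsomes and NADPH, with a stated time of 30 min, tested at 1 uM (on this read-out higher numbers stand for fast clearance and lower numbers for slow clearance), compound 2 stands highest of the two, at 99 mL.min-1.g-1. Compound 3 `Nc1ccc(S(=O)(=O)N2CCN(c3ncc(C(O)(C(F)(F)F)C(F)(F)F)cc3-c3cc4ccccc4s3)CC2)cn1` carries 1-benzothiophen-2-yl in place of 2-methyl-1,3-benzoxazol-5-yl (1-benzothiophen-2-yl in place of 2-methyl-1,3-benzoxazol-5-yl on an aromatic carbon). Among the measured compounds shown here, the only measured step at this place is a 3.7-fold higher number from compound 1 to compound 2 (0.56 log units; beyond the scatter), where 2-methyl-1,3-benzoxazol-5-yl replaced cyclopropyl. That step bears only indirectly, since the entering group also has one five-membered and one six-membered aromatic ring. No change beyond the scatter is therefore expected, and the expected step is a 1.1-fold higher number from compound 2 to compound 3 (0.05 log units; within the scatter). The estimate for compound 3 is 110 mL.min-1.g-1, with an expected range of 50 mL.min-1.g-1 to 240 mL.min-1.g-1.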

Compound 3, intrinsic clearance in microsomes: 315 mL.min-1.g-1
Estimate against measurement, compound 3: 2.9-fold (0.46 log units) below; measured number outside the range, above it.
By their numbers in this assay, from the lowest: compound 1; then compound 2; then compound 3.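

In this assay the position separates two groups that each have one five-membered and one six-membered aromatic ring: 1-benzothiophen-2-yl in place of 2-methyl-1,3-benzoxazol-5-yl gives a 3.2-fold higher number from compound 2 to compound 3 (0.50 log units; beyond the scatter). Against cyclopropyl the same group gives a 12-fold higher number from compound 1 to compound 3 (1.07 log units; beyond the scatter), so the choice of group at this place spans a large step on the shared core. Nothing available here accounts for the gap between the two groups. As far as these compounds go, it remains open whether a carboxylic acid or a morpholine at this place would stay close to compound 1, and whether the ring sulfur or the absent methyl carries the difference.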